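Pyridine-fused lactam series: benzyl to ethyl at the quaternary carbon

The source may hold more compounds than are shown below. What is called first, only, known or untested is meant among the compounds shown, and "the series" means these compounds.

Measured so far:
compound 1, `CSC1(C)C(=O)N(c2ccccc2)c2ncccc21` — 53%
compound 2, `CC1(Cc2ccccc2)C(=O)N(c2ccccc2)c2ncccc21` — 0%

Compound 2 stands lowest of the two numbers in a functional assay on the whole organism (Pleural cavity) for inhibition, with Rattus norvegicus as the target, at a dose of 25 mg/kg; on this read-out lower numbers stand for less inhibition and higher numbers for more inhibition at the one dose given (going by the name of the read-out); its nearest neighbour is compound 1, whose value lies far higher. Within the data shown here, the only step measured, a number 53 percentage points lower from compound 1 to compound 2 (beyond the scatter), is large and beyond the scatter, and came with benzyl in place of methylsulfanyl on a saturated ring carbon.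

Compound 3, `CCC1(C)C(=O)N(c2ccccc2)c2ncccc21`, is not yet measured. It differs from compound 2 by methyl in place of phenyl on a saturated chain carbon bound to a saturated ring carbon, so that the benzyl is shortened to ethyl. Among the measured compounds shown here, no measured step covers this change: the step from compound 1 to compound 2 exchanges a sulfur-bearing group for a benzyl, not a benzyl for an alkyl, so it bears on compound 3 only by showing that the group on this carbon can move this read-out a long way. Because compound 2 sits at 0%, any movement can only be upward or none.

Compound 3 is expected to give a modest rise, a number 20 percentage points higher from compound 2 to compound 3 (beyond the scatter), from compound 2. The estimate for compound 3 is 20%, with a range from 0% to 45%.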

Compound 3, a percentage reported as inhibition, in the whole organism at one dose (the size of the read-out at that dose, not a potency): 12%
Compound 3: the middle estimate sits 8 percentage points above what was measured; measured number inside the range.
By their numbers in this assay, from the lowest: compound 2; then compound 3; then compound 1.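

In this assay, the change from benzyl to ethyl gives a number 12 percentage points higher from compound 2 to compound 3 (beyond the scatter) as a modest step, so removing the phenyl does not by itself bring the series back to the level of compound 1. Set against methylsulfanyl, ethyl still gives a number 41 percentage points lower from compound 1 to compound 3 (beyond the scatter) as a large step, so among the three compounds shown, the two with a group of carbon only on this saturated ring carbon, benzyl and ethyl, both stand far under the one with methylsulfanyl, and the loss seen with benzyl is not tied to the phenyl alone. Nothing beyond these inhibition numbers is at hand to account for the gap between methylsulfanyl and the two carbon groups.

Open, on these data alone, is whether the sulfur atom itself goes with the higher number, which a methoxy or a propyl on the same carbon would test against compound 1 and compound 3. Also open, as far as these compounds go, are an amine or a carboxylic acid at this place, and whether the order of the three compounds holds at any dose other than the single one given.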